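A few compounds are considered here, and "the series" means these few. Any claim that something is new, unique, unknown or untested is made for them only; others in the source may bear on it.

Measured compounds:
Compound 1, `Cc1nc(S(C)(=O)=O)ccc1Oc1ncnc(OC2CCN(C(=O)O[C@H](C)CF)CC2)c1F`, gives 196 nM in a functional assay on isolated protein for inhibition of Glucose-dependent insulinotropic receptor (Homo sapiens), read by HTRF and cAMP accumulation; a higher number here means that more compound is needed for the effect, a lower number that less compound is needed.
Compound 2, `Cc1nc(S(C)(=O)=O)ccc1Oc1ncnc(OC2CCN(C(=O)SC3(C)CC3)CC2)c1F`, gives 13.2 nM.
Compound 3, `Cc1nc(S(C)(=O)=O)ccc1Oc1ncnc(OC2CCN(C(=O)C(F)(F)F)CC2)c1F`, gives 151 nM.

Compound 3 stands second highest of the three numbers. Its nearest neighbour is compound 1, with a 1.3-fold lower number from compound 1 to compound 3 (0.11 log units; within the scatter), a gap within the scatter. Its furthest is compound 2, with an 11-fold higher number from compound 2 to compound 3 (1.06 log units; beyond the scatter).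

Compound 4, `Cc1nc(S(C)(=O)=O)ccc1Oc1ncnc(OC2CCN(C(=O)c3ncc(Cl)cn3)CC2)c1F`, has not yet been measured. It differs from compound 3 in one place: 5-chloropyrimidin-2-yl in place of trifluoromethyl on a carbonyl carbon. The group sits on a carbonyl carbon whose other neighbour is an amide-type nitrogen in a ring.

Among the measured compounds shown here, two measured steps bear on this position. For the measured compounds named here, both exchanges on the same carbonyl carbon have been tried: the one from compound 1 to compound 3 left the number essentially unchanged, while the one from compound 2 to compound 3 was large. So exchanges here can move the number a lot or hardly at all, and nothing measured so far involves a ring of the kind entering. Compound 4 is therefore expected to show a 2.5-fold lower number from compound 3 to compound 4 (0.40 log units; beyond the scatter), a modest move towards a lower number, with wide uncertainty. The estimate for compound 4 is 60 nM, within a range of 15 nM to 250 nM.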

Compound 4, half-maximal effective concentration: 6.12 nM
Compound 4: middle estimate off by 9.8-fold (0.99 log units), on the high side; the whole stated range lies above it.
By their numbers in this assay, from the lowest: compound 4; then compound 2; then compounds 3 and 1 (each within the scatter of the next).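

In this assay, the position on this carbonyl carbon turns out to accept an aromatic ring: replacing trifluoromethyl with 5-chloropyrimidin-2-yl gives a large drop (a 25-fold lower number from compound 3 to compound 4 (1.39 log units; beyond the scatter)), and the drop against the oxygen-linked, fluorine-bearing chain is similar in size (a 32-fold lower number from compound 1 to compound 4 (1.51 log units; beyond the scatter)). The same ring also improves on the sulfur-linked methylcyclopropyl group, the best of the earlier groups, though by a more modest step (a 2.2-fold lower number from compound 2 to compound 4 (0.33 log units; beyond the scatter)), which leaves compound 4 with the lowest number of the four. Nothing measured here accounts for this gain.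

Going by these compounds, whether the gain belongs to the ring itself or to its chlorine stays open. A plain phenyl ring or an unchlorinated pyrimidin-2-yl on the same carbonyl carbon would help to separate the two.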